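The source may report more compounds than this note shows. Statements on the series, on what has been measured and on what is new or still open speak of the compounds shown alone.

Measured so far:
Compound 1 `C[Si](C)(C)c1cccc2[nH]ncc12`: 43000 nM
Compound 2 `OC(Cc1ccccc1)c1cccc2[nH]ncc12`: 7900 nM

In an assay for binding affinity to Indoleamine 2,3-dioxygenase 1 (Homo sapiens), read by spectrophotometry, with a stated time of 30 min (a higher number here means weaker binding, a lower number tighter binding), compound 1 gives 43000 nM, while compound 2 gives 7900 nM. Compound 2 thus stands at the lower of the two numbers, and the gap to compound 1 lies beyond the scatter. Among the compounds with values here, no step between these two has been worked out, so only the two values themselves speak.

Compound 3 `Cc1cc(C(O)Cc2ccccc2)c2cn[nH]c2c1` differs from compound 2 in one place: methyl in place of hydrogen on an aromatic carbon. Within the data shown here, no measured pair shows the effect of this change, so the expectation is a small step, if any, not clearly beyond the scatter, estimated as a 1.2-fold lower number from compound 2 to compound 3 (0.08 log units; within the scatter). Compound 3 is therefore expected at 6500 nM, within a range from 2000 nM to 20000 nM.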

Compound 3, dissociation constant: 470 nM
Compound 3: the middle estimate sits 14-fold (1.14 log units) above what was measured; the whole stated range lies above it.
By their numbers in this assay, from the lowest: compound 3; then compound 2; then compound 1.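

Methyl in place of hydrogen on an aromatic carbon, para to a fused ring, brings a 17-fold lower number from compound 2 to compound 3 (1.23 log units; beyond the scatter) in this assay and so lowers the number well beyond the scatter. This shows that this position, which carries hydrogen in compound 1 and compound 2, responds strongly to the addition of one carbon. Nothing available accounts for a step of this size. From the compounds shown here alone, whether other groups at this position, such as ethyl, methoxy, chlorine or an amine, would match methyl remains open. So does whether the same step would appear with the trimethylsilyl group of compound 1 in place of the side chain of compound 3.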